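The source may report more compounds than this note shows. Statements on the series, on what has been measured and on what is new or still open speak of the compounds shown alone.

Measured so far in a functional assay on HL-60 cells (Homo sapiens) for cytotoxicity, read by MTT assay, with a stated time of 48 h; a higher number here means a weaker inhibitor, a lower number a stronger inhibitor:
compound 1 `O=C(O)CN1C(=O)/C(=C/c2nc3ccccc3n2Cc2ccc(F)cc2)SC1=S` — 1420 nM
compound 2 `O=C(O)CN1C(=O)/C(=C/c2nc3ccccc3n2Cc2ccc(Cl)cc2)SC1=S` — 2650 nM
compound 3 `O=C(O)CN1C(=O)/C(=C/c2nc3cc(Cl)ccc3n2Cc2ccccc2F)SC1=S` — 870 nM

Between compound 2 and compound 1 the change is fluoro in place of chloro on an aromatic carbon, and in this assay it gave a 1.9-fold lower number from compound 2 to compound 1 (0.27 log units; within the scatter). Compound 3 has the lowest of the three numbers; its gap to compound 1 is within the scatter, and only its gap to compound 2 lies beyond it. The difference between the core of compound 2 and the core of compound 3 is not broken down here.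

Compound 4 `O=C(O)CN1C(=O)/C(=C/c2nc3cc(F)ccc3n2Cc2ccccc2F)SC1=S` is not yet measured. It differs from compound 3 by fluoro in place of chloro on an aromatic carbon. This is the same kind of change as from compound 2 to compound 1, but not the same: there the aromatic carbon sits para to a large group, here it belongs to a ring that is part of a fused or bridged system of two rings, meta to a fused ring and para to a fused ring. A small step is expected for compound 4, estimated at a 1.3-fold lower number from compound 3 to compound 4 (0.13 log units; within the scatter), because the earlier step of a 1.9-fold lower number from compound 2 to compound 1 (0.27 log units; within the scatter) stayed within the scatter. Compound 4 is therefore expected to give about 650 nM in this assay, with a likely range from 300 nM to 1400 nM.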

Compound 4, half-maximal inhibitory concentration: > 50000 nM
Compound 4: no number, only a limit; the forecaster's own chance of this, stated with the estimate: 3%; middle value at least 76-fold (1.88 log units) away from the limit.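

In this assay, fluoro in place of chloro on an aromatic carbon gave an at least 57-fold higher number from compound 3 to compound 4 (1.75 log units; beyond the scatter), and this step does not match the earlier one on the other core: the same change on two cores in this assay, a 1.9-fold lower number (0.27 log units; within the scatter) from compound 2 to compound 1 and an at least 57-fold higher number (1.75 log units; beyond the scatter) from compound 3 to compound 4, at least 100-fold (2.03 log units) apart, beyond the scatter of two such steps. The entry for compound 4 is a limit of the assay, not a number: the limit of > 50000 nM in this assay, at which 1 of the 4 values shown sits. The two steps lie at different places on different cores, so these pairs show that the change does not carry over here, but not whether the place or the core accounts for the gap, nor the full size of the new step.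

On these data alone, it remains open whether bromo, methyl or methoxy on that same aromatic carbon would track compound 3 or compound 4.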